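Shortening the ester chain of a thiophene dihydropyrimidinone

The source may report more compounds than this note shows. Statements on the series, on what has been measured and on what is new or still open speak of the compounds shown alone.

Compound 1 `CCCOC(=O)C1=C(C)NC(=S)NC1c1ccco1` and compound 2 `CC1=C(C(=O)OCC(C)C)C(c2ccco2)NC(=S)N1` share one core and differ only in the ester chain, the change from compound 2 to compound 1 being (hydrogen in place of methyl on a saturated chain carbon bound to two saturated chain carbons). In an assay on membranes from HEK293 cells for displacement of a labelled ligand from adenosine receptor A2b (Homo sapiens), read by scintillation counting, with a stated time of 30 min, tested at 1 uM (on this read-out higher numbers stand for more inhibition at the one concentration tested (going by the name of the read-out) and lower numbers for less inhibition), compound 1 gives 46%, while compound 2 gives 18%, so that a number 28 percentage points higher from compound 2 to compound 1 (beyond the scatter). Compound 3 `CCC(CC)OC(=O)C1=C(C)NC(=O)NC1c1cccs1` carries a different core; how its core differs from that of compound 2 is not broken down here. In this assay compound 3 gives 6%, the lowest of the three numbers, with compound 2 the nearest of the other two.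

Compound 4 `CCC(C)OC(=O)C1=C(C)NC(=O)NC1c1cccs1` is not yet measured. It arises from compound 3 by hydrogen in place of methyl on a saturated chain carbon, two bonds along the chain from an oxygen next to a carbonyl group. Going by the values given here, this is the same kind of change as the one from compound 2 to compound 1, but not the same: there the place was a saturated chain carbon bound to two saturated chain carbons, whereas here the place is a saturated chain carbon, two bonds along the chain from an oxygen next to a carbonyl group. The step is expected to be smaller than a number 28 percentage points higher from compound 2 to compound 1 (beyond the scatter), since compound 3 starts from 6% and the place of the change is not the same. For compound 4 the step in this assay is estimated as a number 9 percentage points higher from compound 3 to compound 4 (within the scatter). Compound 4 is therefore expected to give about 15%, between 0% and 35%.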

Compound 4, a percentage reported as inhibition, at one concentration (the size of the read-out at that concentration, not a potency): 7%
The estimate for compound 4 lay 8 percentage points above the measured number; the range from low to high includes it.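

In this assay, removing a methyl from the ester chain does not carry over from the core of compound 2 to the core of compound 3, and the two steps clearly differ: the same change on two cores in this assay, a number 28 percentage points higher (beyond the scatter) from compound 2 to compound 1 and a number 1 percentage points higher (within the scatter) from compound 3 to compound 4, 27 percentage points apart, beyond the scatter of two such steps. Going by these compounds alone, the new step reads a number 1 percentage points higher from compound 3 to compound 4 (within the scatter), and both members of the new pair stay low, with compound 3 at 6% and compound 4 at 7%, so the clear gain seen on the first core has no counterpart on the second. Within the data shown here, this shows that the size of the step cannot be transferred from one core to the other, but with only one pair on each core it does not show which part of the core goes with the difference, nor whether the two steps would differ in the same way for other ester chains.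

The compounds shown leave open how a longer chain, a cyclohexyl ester or an amide in place of the ester would read on either core. Also open, from the compounds shown here alone, is what a change of the core alone would do with the ester chain held fixed, and whether a pair on a third core would follow either of the two steps.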